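Swapping the Aryl Ketone: Methoxyphenyl to Difluorophenyl

A few compounds are considered here, and "the series" means these few. Any claim that something is new, unique, unknown or untested is made for them only; others in the source may bear on it.

Measured in a functional assay on NCI-H226 cells (Homo sapiens) for cytotoxicity, read by sulforhodamine B assay, with a stated time of 48 h, tested at 1 uM; on this read-out lower numbers stand for a stronger effect and higher numbers for a weaker effect at the one concentration tested:
compound 1, `COc1cc(-c2cc(/C=C/C(=O)c3ccc(N)cc3)[nH]n2)cc(OC)c1OC`, gives 88%;
compound 2, `COc1cc(-c2cc(/C=C/C(=O)c3ccc(Cl)c(Cl)c3)[nH]n2)cc(OC)c1OC`, gives 96%;
compound 3, `COc1ccc(C(=O)/C=C/c2cc(-c3cc(OC)c(OC)c(OC)c3)n[nH]2)cc1`, gives 92%.

Compound 3 stands second highest of the three numbers. Its nearest neighbour is compound 1, as seen in a number 4 percentage points higher from compound 1 to compound 3 (within the scatter), and its furthest is compound 2, as seen in a number 4 percentage points lower from compound 2 to compound 3 (within the scatter); all three values lie within the scatter of one another, so no order among them can be read from these numbers.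

Compound 4, `COc1cc(-c2cc(/C=C/C(=O)c3ccc(F)c(F)c3)[nH]n2)cc(OC)c1OC`, differs from compound 3 in one place: 3,4-difluorophenyl in place of 4-methoxyphenyl on a carbonyl carbon. Going by the values given here, two measured steps bear on this change. The most direct is a number 4 percentage points lower from compound 2 to compound 3 (within the scatter), which exchanges a dihalogenated phenyl for the 4-methoxyphenyl at the same carbonyl carbon, in the opposite direction to the step now taken. The other is a number 8 percentage points higher from compound 1 to compound 2 (within the scatter), another exchange of the aryl group on that carbonyl carbon. Both were within the scatter, so a step in either direction that stays within the scatter is expected here, with a slight lean toward the dihalogenated end of the measured range.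

Compound 4 is therefore estimated at 94%, with a range from 85% to 101%, which would mean an expected a number 2 percentage points higher from compound 3 to compound 4 (within the scatter).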

Compound 4, a percentage reported as activity, at one concentration (the size of the read-out at that concentration, not a potency): 95%
Compound 4: the middle estimate sits 1 percentage points below what was measured, and the stated range covers the measured number.
By their numbers in this assay, from the lowest: compounds 1, 3, 4 and 2 (each within the scatter of the next).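

At the carbonyl carbon, the 3,4-difluorophenyl group gives a fourth aryl group in this assay and the read-out stays within the range of the others, with a number 3 percentage points higher from compound 3 to compound 4 (within the scatter) and a number 1 percentage points lower from compound 2 to compound 4 (within the scatter) and also a number 7 percentage points higher from compound 1 to compound 4 (within the scatter) as its steps. Going by these compounds alone, the step from 3,4-dichlorophenyl to 3,4-difluorophenyl is the first that exchanges one halogen for another on an aryl group otherwise named alike, and it shows no change that can be told from the scatter, just as the exchanges against 4-methoxyphenyl and 4-aminophenyl show none. No measurement shown here offers any explanation for these values.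

With all four aryl groups giving values within the scatter of their neighbours at the one concentration tested, the compounds shown leave open whether any group on this carbonyl carbon can move the read-out beyond the scatter at all. A carboxylic acid, a dimethylamino group or a longer chain at this place could answer that, as could a change elsewhere on the shared core.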